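The source may hold more compounds than are shown below. What is called first, only, known or untested is meant among the compounds shown, and "the series" means these compounds.

In a functional assay on NCI-H292 cells (Homo sapiens) for cytotoxicity, read by MTT assay, with a stated time of 72 h, tested at 5 ug/mL (a higher number here means more inhibition of growth at the concentration tested, a lower number less inhibition of growth), compound 1 (`O=C1NC(=S)/C(=C/c2ccc(Cl)cc2)S1`) gives 35.8%. Two related compounds were measured alongside it: compound 2 (`O=C1NC(=S)/C(=C/c2cc(Cl)cc(Cl)c2Cl)S1`) gives 39.7%, and compound 3 (`O=C1NC(=S)/C(=C/c2ccccc2Cl)S1`) gives 34.2%. Compound 1 therefore stands within the usual scatter of both, and the three values cannot be told apart in this measurement. The unmeasured compound 4 (`O=C1NC(=S)/C(=C/c2ccc(F)cc2)S1`) differs from compound 1 at a single place, with fluoro in place of chloro on an aromatic carbon.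

For the measured compounds named here, no two measured compounds differ in only one place, so the data offer no direct measure of any single change, and none of this exchange. Going by the values given here, all three measured compounds carry chloro, and no measured compound carries fluoro. Among the compounds with values here, the only guide is the narrow spread of the values, with compound 3 at 34.2% and compound 2 at 39.7%. On that basis, no change beyond the scatter is expected in this assay, and any drift in either direction should be small. The expected step is a number 2.8 percentage points lower from compound 1 to compound 4 (within the scatter), which is estimated to stay within the scatter. For compound 4 the expected value is 33%, with an estimated range from 21% to 45%.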

Compound 4, percent growth inhibition at one concentration: 31.6%
Compound 4: the middle estimate sits 1.4 percentage points above what was measured; the range from low to high includes it.
By their numbers in this assay, from the lowest: compounds 4, 3, 1 and 2 (each within the scatter of the next).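

For the compounds shown here, the exchange of chloro for fluoro on an aromatic carbon, para to a group of 8 heavy atoms, gives the first single-place comparison in this assay, and it amounts to a number 4.2 percentage points lower from compound 1 to compound 4 (within the scatter). Going by these compounds alone, since all the earlier compounds carried chloro, they could not show whether the growth inhibition seen with them depended on that halogen, whereas this pair shows that, at this position, fluoro can take the place of chloro without a change that can be told from the scatter. No separate measurement is available that could account for this result or connect it to any property of either group.

The pair speaks only to these two halogens at this one position, so it leaves open whether an amine, a methoxy group or a carboxylic acid in the same place would also leave the growth inhibition within the scatter of compound 1. It also leaves open whether fluoro in place of chloro would behave the same way at the other ring positions where compound 2 and compound 3 carry chloro.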